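From Methyl to Hydrogen on Compound 2

A few compounds are considered here, and "the series" means these few. Any claim that something is new, unique, unknown or untested is made for them only; others in the source may bear on it.

Measured in a functional assay on HCT-116 cells (Homo sapiens) for inhibition, read by CCK-8 assay, with a stated time of 48 h; a higher number here means a weaker inhibitor, a lower number a stronger inhibitor:
Compound 1 `COc1cc(-c2cc3nccc(-c4c[nH]c5ccccc45)n3n2)cc(OC)c1OC`: > 10000 nM
Compound 2 `COc1cc(-c2ccnc3cc(-c4ccc(C)cc4)nn23)cc(OC)c1OC`: 48 nM

The value of compound 1, > 10000 nM, is a limit of the assay and not a number. Within the data shown here, compound 2, at 48 nM, is therefore the only compound with a true number in this assay, and it gives the sole reference point for what follows.

Compound 3 `COc1cc(-c2ccnc3cc(-c4ccccc4)nn23)cc(OC)c1OC` keeps the core of compound 2 but has hydrogen in place of methyl on an aromatic carbon, para to a large group, so that 4-methylphenyl becomes phenyl (hydrogen in place of methyl on an aromatic carbon). Among the measured compounds shown here, no measured pair shows what this change does in this assay, so any expectation remains uncertain. The change is a single methyl, and compound 2 at 48 nM is the starting point, so a collapse of inhibition seems unlikely. The step of a 1.9-fold higher number from compound 2 to compound 3 (0.27 log units; within the scatter) is expected to be small, near the edge of the usual scatter, and towards weaker inhibition. For compound 3 the estimated value is 90 nM, with an expected range from 30 nM to 350 nM.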

Compound 3, half-maximal inhibitory concentration: 3880 nM
For compound 3 the middle estimate is 43-fold (1.63 log units) below the measured one; the whole stated range lies below it.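

In this assay the methyl on the aromatic carbon, para to a large group, proves far from a minor detail: the change from 4-methylphenyl to phenyl brings an 81-fold higher number from compound 2 to compound 3 (1.91 log units; beyond the scatter) and removes only one heavy atom. Among these compounds, this is the first measured step, and it shows that inhibition on the core of compound 2 depends strongly on this single position. Compound 3 still gives a true number and does not reach the ceiling of the measurement, which is itself a limit and not a number: the limit of > 10000 nM in this assay, at which 1 of the 3 values shown sits.

From the compounds shown here alone, whether an ethyl group, a methoxy group or a chlorine atom at the same place would hold inhibition near the level of compound 2 stays open, so it cannot yet be said if methyl is special here or if any group at this position would serve. This single pair gives no cause for the size of the step, and it does not tell whether the same change would weigh as heavily on another core, such as that of compound 1.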